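Methoxy for methyl on the pendant aryl ring

A few compounds are considered here, and "the series" means these few. Any claim that something is new, unique, unknown or untested is made for them only; others in the source may bear on it.

Going by the values given here, compound 2 `Cc1ccc(-c2scc3c2CCOC32CCN(Cc3ccccc3)CC2)cc1` gives 3.6 nM in an assay on membranes from brain for displacement of a labelled ligand from Sigma non-opioid intracellular receptor 1 (Cavia porcellus), read by scintillation counting, with a stated time of 120 min (on this read-out higher numbers stand for weaker inhibition and lower numbers for stronger inhibition), and compound 1 `c1ccc(CN2CCC3(CC2)OCCc2c3csc2-c2ccccc2)cc1` gives 4.5 nM; the two sit within the scatter of each other, the only measured step being a 1.3-fold lower number from compound 1 to compound 2 (0.10 log units; within the scatter). Compound 3 `COc1ccc(-c2scc3c2CCOC32CCN(Cc3ccccc3)CC2)cc1` differs from compound 2 by methoxy in place of methyl on an aromatic carbon. Among the compounds with values here, no measured step covers a methoxy at that place; the single step on that ring, hydrogen to methyl, stayed within the scatter, so the expected step of a 1.1-fold higher number from compound 2 to compound 3 (0.05 log units; within the scatter) is small, with no direction beyond the scatter. For compound 3 the estimate in this assay is 4 nM, expected between 1.5 nM and 11 nM.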

Compound 3, inhibition constant: 1.5 nM
The estimate for compound 3 lay 2.7-fold (0.43 log units) above the measured number; the measured number falls inside the stated range.
By their numbers in this assay, from the lowest: compound 3; then compounds 2 and 1 (each within the scatter of the next).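

In this assay, going by these compounds alone, methoxy is the first change at this place, para to a large group, to move the number beyond the scatter, giving a 2.4-fold lower number from compound 2 to compound 3 (0.38 log units; beyond the scatter) and a 3.0-fold lower number from compound 1 to compound 3 (0.48 log units; beyond the scatter). Hydrogen to methyl had stayed within the scatter, so this position does respond to its substituent, and methoxy separates from both hydrogen and methyl.

As far as these compounds go, whether a hydroxyl, an ethoxy or an amine at this place would extend the step remains open. Nothing available accounts for the difference methoxy makes here.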